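The compounds below may be only part of what the source reports. "The series", "measured", "known", "first", "only" and "open" are said of these compounds alone.

Of the compounds shown here, three that share a core have been tested in an ADME assay on RD cells (Homo sapiens) for cytotoxicity, read by MTT assay, with a stated time of 3 days; on this read-out higher numbers stand for lower toxicity in this test and lower numbers for higher toxicity in this test. Compound 1 `CC[C@@H](CCn1cncn1)c1ccc(C)cc1` gives 79.4 ug/mL. Compound 2 `CC[C@@H](CCn1cncn1)c1ccc(OC)cc1` gives 115 ug/mL; it differs from compound 1 by methoxy in place of methyl on an aromatic carbon, and that step came to a 1.4-fold higher number from compound 1 to compound 2 (0.16 log units; within the scatter). Compound 3 `CCC[C@H](CCn1cncn1)c1ccc(C)cc1` gives 47.2 ug/mL, the lowest of the three numbers; how its core differs from the core of compound 1 is not broken down here.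

Compound 4 `CCC[C@H](CCn1cncn1)c1ccc(OC)cc1` has not yet been measured. It differs from compound 3 by methoxy in place of methyl on an aromatic carbon, which is the same change that separates compound 1 from compound 2, made at the same place. Within the data shown here, the only guide to its size is that earlier step, which in this assay was a 1.4-fold higher number from compound 1 to compound 2 (0.16 log units; within the scatter), so a step of similar size is expected here, namely a 1.4-fold higher number from compound 3 to compound 4 (0.15 log units; within the scatter). On that basis compound 4 is expected to give 66 ug/mL, with a likely range from 35 ug/mL to 125 ug/mL. The measured number for compound 4 in this assay will show whether this expectation holds.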

Compound 4, half-maximal cytotoxic concentration: 59.3 ug/mL
Beside the measured number, compound 4's estimate is 1.1-fold (0.05 log units) above it; measured number inside the range.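

In this assay, methoxy in place of methyl on the aromatic carbon gave a 1.3-fold higher number from compound 3 to compound 4 (0.10 log units; within the scatter). Set beside the earlier step, the change behaved alike on the two cores: the same change on two cores in this assay, a 1.4-fold higher number (0.16 log units; within the scatter) from compound 1 to compound 2 and a 1.3-fold higher number (0.10 log units; within the scatter) from compound 3 to compound 4, 1.2-fold (0.06 log units) apart, within the scatter of two such steps. This shows that, between these two cores, the size of the step did not shift beyond the scatter, but each step on its own also lies within the scatter, so it does not show that methoxy really moves the number, and two cores cannot speak for the whole series.

The compounds shown carry only methyl or methoxy at this place, so it remains open how a quite different group there, such as an amine or a carboxylic acid, would change the number. Going by these compounds, it also remains open whether the step from methyl to methoxy would stay the same on a core with a longer chain.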